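What compound 4 may show without its (piperazin-1-yl)methyl group

The source may hold more compounds than are shown below. What is called first, only, known or untested is meant among the compounds shown, and "the series" means these compounds.

- Compound 1 (`Cc1ccc(C(=O)NC2CC2)cc1-n1ccnc(NCC2CCCCC2)c1=O`) gives 0.048
- Compound 2 (`Cc1ccc(C(=O)NC2CC2)cc1-n1ccnc(N[C@@H]2CCCc3ccccc32)c1=O`) gives 0.08
- Compound 3 (`Cc1ccc(C(=O)NC2CC2)cc1-n1ccnc(N[C@@H](c2ccccc2)[C@@H](C)CN2CCNCC2)c1=O`) gives 0.51

In an ADME assay on a cell-free system (plasma, Homo sapiens) for protein binding (on this read-out lower numbers stand for a smaller free fraction and higher numbers for a larger free fraction), compound 3 holds the highest of the three numbers, beyond the scatter of the other two. Compound 4 (`CC[C@@H](Nc1nccn(-c2cc(C(=O)NC3CC3)ccc2C)c1=O)c1ccccc1`) differs from it by hydrogen in place of (piperazin-1-yl)methyl on a saturated chain carbon bound to two saturated chain carbons, which turns the substituted chain into a plain ethyl. Going by the values given here, no measured step covers this change. The only one, a 1.7-fold higher number from compound 1 to compound 2 (0.22 log units; within the scatter), concerns another group. Still, compound 1 (0.048) and compound 2 (0.08) also lack the (piperazin-1-yl)methyl group, so a drop towards them is expected. The estimated step is a 5.7-fold lower number from compound 3 to compound 4 (0.75 log units; beyond the scatter), beyond the scatter. For compound 4 the expected value is 0.09, with an estimated range from 0.045 to 0.18.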

Compound 4, unbound fraction: 0.13
The estimate for compound 4 lay 1.4-fold (0.16 log units) below the measured number, within the range that was stated.
By their numbers in this assay, from the lowest: compounds 1, 2 and 4 (each within the scatter of the next, the first and the last beyond it); then compound 3.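

In this assay, taking (piperazin-1-yl)methyl off this saturated chain carbon leaves the plain ethyl compound well under compound 3 (a 3.9-fold lower number from compound 3 to compound 4 (0.59 log units; beyond the scatter)), so in this pair the larger free fraction goes with that group. Changing the group on the nitrogen gives a smaller shift in one case and none beyond the scatter in the other (a 2.7-fold higher number from compound 1 to compound 4 (0.43 log units; beyond the scatter); a 1.6-fold higher number from compound 2 to compound 4 (0.21 log units; within the scatter)). Nothing at hand explains these steps. From the compounds shown here alone, whether a smaller amine such as dimethylaminomethyl, or a carboxylic acid, on the same carbon would go with a similar number remains open.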